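A few compounds are considered here, and "the series" means these few. Any claim that something is new, unique, unknown or untested is made for them only; others in the source may bear on it.

Three compounds of this series have so far been run through a physicochemical assay for lipophilicity, using the shake flask method, in phosphate buffer, measured as octanol-water partition, with a stated time of 30 min, at pH 7.4; a higher number here means a more lipophilic compound, a lower number a more polar compound. Compound 1, `Cc1nccn1-c1cnc(NCc2c(F)ccc3c2CCO3)c2cn[nH]c(=O)c12`, gives 2.1 in this assay. Compound 2, `Cc1ncccc1-c1cnc(NCc2c(F)ccc3c2CCO3)c2n[nH]c(=O)n12`, gives 2.5. Compound 3, `CN(c1ccccc1)c1cnc(NCc2c(F)ccc3c2CCO3)n2cnnc12`, gives 3.6, the highest of the three numbers; compound 2 is its nearest neighbour and lies lower by more than the scatter, and compound 1 lies further down, also beyond the scatter. No two of these measured compounds differ in only one place, so no single step can be read off between them; the three values stand on their own.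

Compound 4, `CN(c1cccnc1)c1cnc(NCc2c(F)ccc3c2CCO3)n2cnnc12`, is the next compound to be measured. Set against compound 3 it differs in one place: pyridin-3-yl in place of phenyl on a nitrogen on an aromatic ring. The shared core and the rest of the molecule are unchanged.

With no measured step of this kind in the series, the expectation rests on the counted change alone and on the starting point of compound 3 at 3.6 in this assay. A decrease beyond the scatter is expected, the estimated step being a number 1.20 log units lower from compound 3 to compound 4 (beyond the scatter). Compound 4 is accordingly estimated at 2.4, with the likely range running from 1.8 to 3.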

Compound 4, distribution coefficient: 2.6
Beside the measured number, compound 4's estimate is 0.20 log units below it, and the stated range covers the measured number.
By their numbers in this assay, from the lowest: compound 1; then compounds 2 and 4 (each within the scatter of the next); then compound 3.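

Among these compounds, the pair formed by compound 3 and compound 4 is the first to differ in only one place, and it gives this position a measured size in this assay: pyridin-3-yl in place of phenyl on a nitrogen on an aromatic ring gives a number 1.00 log units lower from compound 3 to compound 4 (beyond the scatter). The counted change behind that step is small: the heavy-atom count stays the same, neither group carries a net charge, one ring carbon gives way to a ring nitrogen, and only pyridin-3-yl has a hydrogen-bond acceptor. No accompanying measurement bears on the origin of the step, so this pair fixes its size and direction but gives no explanation for it.

The compounds shown leave open whether pyridin-4-yl, or a saturated ring such as piperidine, would give a step of similar size at this position in this assay. As far as these compounds go, it also remains open whether the same exchange would carry over to the core of compound 1 or the core of compound 2, since this single pair rests on the shared core of compound 3 and compound 4 alone.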